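Saturating the Dienoyl Chain of a Trimethoxyphenyl Amide

The source may report more compounds than this note shows. Statements on the series, on what has been measured and on what is new or still open speak of the compounds shown alone.

Compound 2 `C/C=C/C=C/C(=O)N(Cc1ccc(OC)c(O)c1)c1cc(OC)c(OC)c(OC)c1` gives 140 nM in a functional assay on MGC-803 cells (Homo sapiens) for inhibition, read by MTT assay, with a stated time of 48 h (a lower number here means a stronger inhibitor, a higher number a weaker inhibitor), the lowest of the two numbers measured there. Compound 1 `C/C=C/C(=O)N(Cc1cccc(O)c1)c1cc(OC)c(OC)c(OC)c1` gives 14100 nM in this assay, a far higher number that lies well beyond the scatter. Compound 3 `COc1cc(NCc2ccccc2)cc(OC)c1OC` is recorded in this assay only as a limit, > 80000 nM, one of the three results sitting at that boundary (the limit of > 80000 nM in this assay, at which 1 of the 3 values shown sits).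

Compound 4 `CCCCC(=O)N(Cc1ccc(OC)c(O)c1)c1cc(OC)c(OC)c(OC)c1` differs from compound 2 in one place: butyl in place of penta-1,3-dien-1-yl on a carbonyl carbon. Among the measured compounds shown here, no measured pair anchors this single change. The expected step is an 11-fold higher number from compound 2 to compound 4 (1.03 log units; beyond the scatter), a loss of potency beyond the scatter. Compound 4 is therefore estimated at 1500 nM in this assay, within a range from 300 nM to 8000 nM.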

Compound 4, half-maximal inhibitory concentration: 66 nM
Beside the measured number, compound 4's estimate is 23-fold (1.36 log units) above it; measured number below the stated range.
By their numbers in this assay, from the lowest: compound 4; then compound 2; then compound 1. At a limit, above all of these: compound 3.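

At this position, on a carbonyl carbon whose other neighbours are an amide-type nitrogen, the two double bonds of penta-1,3-dien-1-yl are not required for potency in this assay: butyl in their place gives a 2.1-fold lower number from compound 2 to compound 4 (0.33 log units; beyond the scatter), a modest gain. The earlier compounds shown here could not show this, since no two of them differed in one place. Nothing at hand gives a cause for this step. Still open, on these data alone, is how a longer chain, such as hexyl, or an amine or carboxylic acid carried on the butyl chain would fare here.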